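Aryl substitution on the sulfonamide and receptor binding

A few compounds are considered here, and "the series" means these few. Any claim that something is new, unique, unknown or untested is made for them only; others in the source may bear on it.

Compound 3 `O=C(NCc1ccc(CNS(=O)(=O)c2ccccc2)cc1)c1ccc(CNc2ncccn2)cc1` gives the lowest number of the three measured compounds in an assay on MDA-MB-231 cells for binding affinity to C-X-C chemokine receptor type 4 (Homo sapiens), read by microscopy, with stated times of 10 min and 30 min (a lower number here means that less compound is needed, a higher number that more compound is needed for the effect), at 1 nM. Compound 1 `O=C(NCc1ccc(CNS(=O)(=O)c2ccc(-c3ccc(F)cc3)cc2)cc1)c1ccc(CNc2ncccn2)cc1` gives 1000 nM in this assay, and compound 2 `O=C(NCc1ccc(CNS(=O)(=O)c2cccc(C(F)(F)F)c2)cc1)c1ccc(CNc2ncccn2)cc1` gives 1000 nM. Both steps toward compound 3 are large: a 1000-fold lower number from compound 1 to compound 3 (3.00 log units; beyond the scatter) and a 1000-fold lower number from compound 2 to compound 3 (3.00 log units; beyond the scatter). Compound 4 `O=C(NCc1ccc(CNS(=O)(=O)c2ccc(F)cc2)cc1)c1ccc(CNc2ncccn2)cc1` is the next member; it differs from compound 3 by fluoro in place of hydrogen on an aromatic carbon, the entering group counting 1 heavy atom and sitting on an aromatic carbon of a six-membered aromatic ring of carbon only, para to a large group. The two measured steps bear on this change, since both show that a group entering on this ring of the shared core raised the number greatly, yet in neither case was the entering group a single fluorine. A rise in the number is therefore expected for compound 4, but one smaller than either measured step, estimated as a 20-fold higher number from compound 3 to compound 4 (1.30 log units; beyond the scatter). Compound 4 is expected to give 20 nM in this assay, within a range of 2 nM to 300 nM.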

Compound 4, effective concentration (reported as EC, without a stated level of effect): > 1000 nM
Compound 4: no number, only a limit (the forecaster's own chance of this, stated with the estimate: 5%); middle value at least 50-fold (1.69 log units) away from the limit.
By their numbers in this assay, from the lowest: compound 3; then compounds 1 and 2 (each within the scatter of the next).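

A single fluoro on an aromatic carbon, para to a large group, is enough for a large step in this assay. The larger entering groups of compound 1 and compound 2 are therefore not needed for a large rise, since an entering group of 1 heavy atom also gives one on this ring. For compound 4, > 1000 nM is a limit of the assay and not a number, and the step reads an at least 1000-fold higher number from compound 3 to compound 4 (3.00 log units; beyond the scatter): the limit of > 1000 nM in this assay, at which 1 of the 4 values shown sits.

Two further steps cannot be read in size: a number no lower from compound 2 to compound 4 (the limit leaves the size open) and a number no lower from compound 1 to compound 4 (the limit leaves the size open). Any ranking among these three compounds stays open. Also open, going by these compounds, is whether a methyl, a methoxy or an amine on the same aromatic carbon would keep the number close to that of compound 3.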